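The source may report more compounds than this note shows. Statements on the series, on what has been measured and on what is new or still open speak of the compounds shown alone.

The account follows a single structural step in a functional assay on L1210/0 cells (Mus musculus) for antiproliferative activity, read by MTT assay, with a stated time of 72 h (on this read-out lower numbers stand for stronger inhibition and higher numbers for weaker inhibition), from compound 1 to compound 3, with compound 2 standing beside them as the only measured point.

Compound 1, `O=C1O/C(=C\Cn2cnc3c(F)nc(F)c(Cl)c32)C(OCc2ccccc2)=C1OCc1ccccc1`, was run in this assay but has no number: in this assay compound 1 gives "not determined" (no result reported), so compound 1 stands nowhere on the scale and offers no anchor of its own.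

Compound 2, `O=C1NC(O)(CCn2cnc3cc[nH]c3c2=O)C(OCc2ccccc2)=C1OCc1ccccc1`, shares the two benzyloxy-bearing ring substituents but carries a different core. In this assay compound 2 gives 107000 nM, a weak result.

Compound 3, `O=C1O/C(=C\Cn2cnc3cncc(Br)c32)C(OCc2ccccc2)=C1OCc1ccccc1`, is reached from compound 1 by the following change: a group of 10 heavy atoms (6 carbon, 3 nitrogen, 1 bromine; one five-membered aromatic ring with 2 hetero atoms, one six-membered aromatic ring with 1 hetero atom) in place of a group of 12 heavy atoms (6 carbon, 3 nitrogen, 2 fluorine, 1 chlorine; one five-membered aromatic ring with 2 hetero atoms, one six-membered aromatic ring with 1 hetero atom), on a saturated chain carbon bound to a double-bonded chain carbon.

Among the compounds with values here, no step between measured compounds exists here, and compound 1 has no value, so the size of the step from compound 1 to compound 3 in this assay cannot be judged from data; the writer expects no shift beyond the usual scatter in either direction, and takes the weak result of compound 2 as the only guide to the series.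

Compound 3 is expected to give about 50000 nM in this assay, estimated to fall between 5000 nM and 300000 nM.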

Compound 3, half-maximal inhibitory concentration: 6800 nM
The estimate for compound 3 lay 7.4-fold (0.87 log units) above the measured number; low and high end bracket the measured number.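

In this assay, within the data shown here, compound 1 gives "not determined" (no result reported), so the result for compound 3, 6800 nM, yields no step that can be read. The compounds shown leave open how the exchange of groups on the saturated chain carbon bears on antiproliferative activity. Nothing at hand speaks to the cause of the result for compound 3.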